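Removing the methoxy from the aryl group of compound 3

A few compounds are considered here, and "the series" means these few. Any claim that something is new, unique, unknown or untested is made for them only; others in the source may bear on it.

Three compounds of the series carry the same hydrazinyl-urea linker to the dichloropyridine and differ at the aryl group and the core. Compound 1 `Cn1ncc2c(-c3ccccc3)cc(NNC(=O)Nc3cc(Cl)nc(Cl)c3)nc21` gives 76900 nM in a functional assay on SW620/5-FU cells (Homo sapiens) for cytotoxicity, read by MTT assay, with a stated time of 48 h, in the presence of a further agent that is not named here; a higher number here means that more compound is needed for the effect, a lower number that less compound is needed. Going by the values given here, compound 2 `Cc1nn(C)c2nc(NNC(=O)Nc3cc(Cl)nc(Cl)c3)cc(-c3ccc(Cl)s3)c12` gives 29400 nM in this assay, and compound 3 `COc1ccc(-c2cc(NNC(=O)Nc3cc(Cl)nc(Cl)c3)nc3c2c(C)nn3C)cc1` gives 9700 nM, the lowest of the three numbers; the step of a 3.0-fold lower number from compound 2 to compound 3 (0.48 log units; beyond the scatter) is the only one-point comparison measured so far, and it changes the aryl group, not the core.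

Compound 4 `Cc1nn(C)c2nc(NNC(=O)Nc3cc(Cl)nc(Cl)c3)cc(-c3ccccc3)c12` differs from compound 3 by hydrogen in place of methoxy on an aromatic carbon. Among the compounds with values here, no measured step bears directly on this change. Compound 1, which shares the phenyl group but carries a different core, gives 76900 nM, a number well above that of compound 3, so its value is only a loose guide. A step toward a higher number is therefore expected, a 3.1-fold higher number from compound 3 to compound 4 (0.49 log units; beyond the scatter), with wide uncertainty. Compound 4 is estimated at 30000 nM, in the range 10000 nM to 90000 nM.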

Compound 4, half-maximal effective concentration: 22900 nM
Compound 4: the middle estimate sits 1.3-fold (0.12 log units) above what was measured; the measured number falls inside the stated range.
By their numbers in this assay, from the lowest: compound 3; then compounds 4 and 2 (each within the scatter of the next); then compound 1.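

In this assay the methoxy group has a readable effect at this position, para to a large group (a 2.4-fold higher number from compound 3 to compound 4 (0.37 log units; beyond the scatter)), whereas phenyl and 5-chlorothiophen-2-yl are not separated (a 1.3-fold lower number from compound 2 to compound 4 (0.11 log units; within the scatter)). Going by these compounds alone, with the phenyl group held constant, the methyl on an aromatic carbon of the core also gives a step of its own (a 3.4-fold lower number from compound 1 to compound 4 (0.53 log units; beyond the scatter)), the first one-point reading of the core. Nothing available accounts for either step.

Still open, from the compounds shown here alone, is whether an ethoxy group, a hydroxyl group or an amine in place of the methoxy would follow the same direction. Going by these compounds, it is also open whether the step for the core methyl holds when the aryl group is 4-methoxyphenyl or 5-chlorothiophen-2-yl rather than phenyl.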